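Swapping cyclohexyl for a pent-2-yn-1-yl chain on the core

The compounds below may be only part of what the source reports. "The series", "measured", "known", "first", "only" and "open" are said of these compounds alone.

Compound 1 `Nc1ccc2cccc(OC3CCCCC3)c2n1` gives the lowest number of the three measured compounds in an assay on cells with melanin-concentrating hormone receptor 1 (Homo sapiens) as the target, read by radioligand binding (on this read-out lower numbers stand for stronger inhibition and higher numbers for weaker inhibition), at 361 nM. Compound 2 `Nc1ccc2cccc(OCCC(F)(F)F)c2n1` gives 722 nM, and compound 3 `CC1CC1COc1cccc2ccc(N)nc12` gives 1640 nM. Both comparisons run in the same direction: a 2.0-fold higher number from compound 1 to compound 2 (0.30 log units; within the scatter) and a 4.5-fold higher number from compound 1 to compound 3 (0.66 log units; beyond the scatter), so replacing cyclohexyl has so far cost potency, modestly at most. Compound 4 `CCC#CCOc1cccc2ccc(N)nc12` differs from compound 1 in one place: pent-2-yn-1-yl in place of cyclohexyl on an oxygen on an aromatic ring. As a chain replaces the ring, the steps to compound 2 and compound 3 bear most directly, and a similar modest weakening is expected, a 2.5-fold higher number from compound 1 to compound 4 (0.40 log units; beyond the scatter). Compound 4 is therefore estimated at 900 nM in this assay, with a range of 350 nM to 2500 nM.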

Compound 4, half-maximal inhibitory concentration: > 2000 nM
Compound 4 gave a limit, no number; the forecaster's own chance of this, stated with the estimate: 5%; at least 2.2-fold (0.34 log units) between middle value and limit.
By their numbers in this assay, from the lowest: compounds 1 and 2 (each within the scatter of the next); then compound 3. At a limit, above all of these: compound 4.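

In this assay compound 4 gave a limit and not a number: the limit of > 2000 nM in this assay, at which 1 of the 4 values shown sits. Placing pent-2-yn-1-yl on this oxygen gives an at least 5.5-fold higher number from compound 1 to compound 4 (0.74 log units; beyond the scatter) and an at least 2.7-fold higher number from compound 2 to compound 4 (0.44 log units; beyond the scatter), so this position does not accept every small open chain equally. The step from the (2-methylcyclopropyl)methyl ether is only a floor, an at least 1.2-fold higher number from compound 3 to compound 4 (0.08 log units; that floor lies within the scatter), and does not separate the two.

As far as these compounds go, how far the true value lies past the limit stays open. So does whether an amine on the chain, or a longer saturated chain, would match cyclohexyl here.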